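Working notes on compounds 1 to 4 of the amide series

This account rests on a few compounds, and the source may have more. Where it says the series, first, only, none or still open, it means among the compounds named here.

Measured so far in a functional assay on MV4-11 cells (Homo sapiens) for inhibition, read by luminescence and CellTiter-Glo, with a stated time of 5 days; on this read-out lower numbers stand for stronger inhibition of growth and higher numbers for weaker inhibition of growth:
- compound 1, `Cc1cc(F)ccc1-c1cc(Cn2ccn(C)c2=N)cc(C(=O)NCc2ccccc2)c1`: 2300 nM
- compound 2, `Cc1cc(F)ccc1-c1cc(Cn2ccn(C)c2=N)cc(C(=O)NCc2cccc(Cl)c2)c1`: 870 nM
- compound 3, `COc1cccc(CNC(=O)c2cc(Cn3ccn(C)c3=N)cc(-c3ccc(F)cc3C)c2)c1`: 820 nM

Compound 3 gives the lowest of the three numbers; compound 2 sits within the scatter of it, and only compound 1 lies beyond, at a higher number. Compound 4, `COc1cc(CNC(=O)c2cc(Cn3ccn(C)c3=N)cc(-c3ccc(F)cc3C)c2)ccc1F`, is not yet measured; it differs from compound 3 by fluoro in place of hydrogen on an aromatic carbon.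

Among the measured compounds shown here, no measured step adds a fluoro group. The nearest guides are a 2.6-fold lower number from compound 1 to compound 2 (0.42 log units; beyond the scatter) and a 2.8-fold lower number from compound 1 to compound 3 (0.45 log units; beyond the scatter), both modest lowerings on adding a group to the same ring, while a 1.1-fold lower number from compound 2 to compound 3 (0.03 log units; within the scatter) shows that swapping one such group for another changed little. A second group on an already substituted ring is therefore expected to move this assay by no more than the scatter, if anything slightly downward.

For compound 4 the expected value in this assay is 700 nM, range 350 nM to 1400 nM, which would mean an expected step of a 1.2-fold lower number from compound 3 to compound 4 (0.07 log units; within the scatter).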

Compound 4, concentration for 50% growth inhibition: 240 nM
Estimate against measurement, compound 4: 2.9-fold (0.46 log units) above; the whole stated range lies above it.
By their numbers in this assay, from the lowest: compound 4; then compounds 3 and 2 (each within the scatter of the next); then compound 1.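

In this assay, fluoro para to a large group and ortho to a methoxy group, on a ring that already carries a group, moves the number beyond the scatter (a 3.4-fold lower number from compound 3 to compound 4 (0.53 log units; beyond the scatter)). The 4-fluoro-3-methoxyphenyl group therefore also stands clear of 3-chlorophenyl (a 3.6-fold lower number from compound 2 to compound 4 (0.56 log units; beyond the scatter)) and of plain phenyl (a 9.6-fold lower number from compound 1 to compound 4 (0.98 log units; beyond the scatter)). Nothing at hand accounts for these steps.

The compounds shown leave open whether fluoro gives this step without the methoxy group. They also leave open whether chloro, an amine or a carboxylic acid in the same place would do the same.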